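Methyl on the sulfonyl ring: a second look

The compounds below may be only part of what the source reports. "The series", "measured", "known", "first", "only" and "open" are said of these compounds alone.

Two measured compounds share one core. Compound 1 `O=C1/C(=C/c2ccncc2)CN(S(=O)(=O)c2ccccc2)C/C1=C\c1ccccc1F` carries a plain phenylsulfonyl group, and compound 2 `Cc1ccc(S(=O)(=O)N2C/C(=C\c3ccncc3)C(=O)/C(=C/c3ccccc3F)C2)cc1` differs from it only by methyl in place of hydrogen on an aromatic carbon. In a functional assay on SMMC-7721 cells (Homo sapiens) for cytotoxicity, read by MTT assay, with a stated time of 24 h (a higher number here means a weaker inhibitor, a lower number a stronger inhibitor), compound 1 gives 17500 nM, while compound 2 gives 13200 nM, so the step runs a 1.3-fold lower number from compound 1 to compound 2 (0.12 log units; within the scatter), a change too small to call a real difference.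

Compound 3 `O=C1/C(=C/c2cccnc2)CN(S(=O)(=O)c2ccccc2)C/C1=C\c1ccccc1C(F)(F)F` is built on a different core, and the difference between the two cores is not broken down here. In this assay compound 3 gives 10900 nM, which lies close to both earlier numbers.

Compound 4 `Cc1ccc(S(=O)(=O)N2C/C(=C\c3cccnc3)C(=O)/C(=C/c3ccccc3C(F)(F)F)C2)cc1` has not been measured. It differs from compound 3 by methyl in place of hydrogen on an aromatic carbon, the same change that turns compound 1 into compound 2, at the same place on the ring.

Because a 1.3-fold lower number from compound 1 to compound 2 (0.12 log units; within the scatter) stayed within the scatter, the expectation is a similarly small step, a 1.3-fold lower number from compound 3 to compound 4 (0.11 log units; within the scatter), resting on one pair only. Compound 4 is therefore estimated at 8500 nM, with a likely range from 4500 nM to 16000 nM.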

Compound 4, half-maximal inhibitory concentration: 6700 nM
The estimate for compound 4 lay 1.3-fold (0.10 log units) above the measured number; the range from low to high includes it.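

In this assay, adding the methyl to the sulfonyl ring on the second core again gives only a small change, with a step of a 1.6-fold lower number from compound 3 to compound 4 (0.21 log units; within the scatter). Set side by side, the two steps show no real difference, so in these two pairs the change carries over from one core to the other about as the first pair suggested: the same change on two cores in this assay, a 1.3-fold lower number (0.12 log units; within the scatter) from compound 1 to compound 2 and a 1.6-fold lower number (0.21 log units; within the scatter) from compound 3 to compound 4, 1.2-fold (0.09 log units) apart, within the scatter of two such steps

This shows that the methyl changes little on both cores, but it does not show that the methyl truly strengthens the compounds, since each step alone is too small to count as a real difference, and two pairs cannot speak for other cores in the series.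

The compounds shown hold only hydrogen or methyl at this place on the ring, so it remains open whether a different group there, such as a methoxy group, an amine or a carboxylic acid, would produce a clear change. Also open, from the compounds shown here alone, is how each of the differences between the core of compound 1 and the core of compound 3 contributes on its own.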